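The compounds below may be only part of what the source reports. "The series", "measured", "known", "first", "only" and "open" are said of these compounds alone.

Measured in an assay on HEK293 cells for displacement of a labelled ligand from 5-hydroxytryptamine receptor 6 (Homo sapiens), with a stated time of 60 min, tested at 1 uM, in the presence of a further agent that is not named here; on this read-out lower numbers stand for a weaker effect and higher numbers for a stronger effect at the one concentration tested:
Compound 1 `COc1cc(N)c(Cl)cc1C(=O)CCC1CCN(CCNS(=O)(=O)c2ccc3c(c2)NC(=O)CO3)CC1` gives 40%.
Compound 2 `COc1ccc(S(=O)(=O)NCCN2CCC(CCC(=O)c3cc(Cl)c(N)cc3OC)CC2)cc1` gives 52%.
Compound 3 `COc1ccc(S(=O)(=O)CCCN2CCC(CCC(=O)c3cc(Cl)c(N)cc3OC)CC2)cc1` gives 33%.

Compound 2 stands highest of the three, with compound 1 nearest and compound 3 furthest, both gaps beyond the scatter. Within the data shown here, the only single-point step, a number 12 percentage points higher from compound 1 to compound 2 (beyond the scatter), exchanges the group on the sulfonyl sulfur. Compound 4 `COc1ccc(S(=O)(=O)NCCN2CCC(CCC(=O)c3cc(Cl)c(N)cc3OC)CC2)c(OC)c1` differs from compound 2 by methoxy in place of hydrogen on an aromatic carbon. Among the measured compounds shown here, no measured step concerns a methoxy added to this ring; the step from compound 1 to compound 2 alters another part of the molecule and gives no direction for the present change. Hence no step beyond the scatter is expected in this assay; the estimated step is a number 2 percentage points lower from compound 2 to compound 4 (within the scatter). Compound 4 is expected to give 50%, within 32% to 68%.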

Compound 4, a percentage reported as inhibition, at one concentration (the size of the read-out at that concentration, not a potency): 45%
The estimate for compound 4 lay 5 percentage points above the measured number, within the range that was stated.
By their numbers in this assay, from the lowest: compounds 3, 1, 4 and 2 (each within the scatter of the next, the first and the last beyond it).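

In this assay, methoxy in place of hydrogen on an aromatic carbon, ortho to a large group, gives a number 7 percentage points lower from compound 2 to compound 4 (within the scatter) and so shows that this position takes the added methoxy without a step beyond the scatter. With 2,4-dimethoxyphenyl on the sulfonyl sulfur, the change from the larger group of compound 1 gives a number 5 percentage points higher from compound 1 to compound 4 (within the scatter) and no longer a step beyond the scatter. No measured evidence bears on this result. Open, from the compounds shown here alone, is whether an amine, a carboxylic acid or fluorine at this position would give a step beyond the scatter.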